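Trimming the amide arm of a pyrazole-type EP1 ligand

The source may report more compounds than this note shows. Statements on the series, on what has been measured and on what is new or still open speak of the compounds shown alone.

Of the compounds shown here, three sharing one core have been measured in an assay on CHO-K1 cells for displacement of a labelled ligand from prostaglandin E2 receptor EP1 subtype (Homo sapiens); a higher number here means a weaker inhibitor, a lower number a stronger inhibitor. Compound 1 `Cc1cc(C(N)=O)nn1Cc1cc(Cl)ccc1OCc1ccccc1` carries a plain primary carboxamide on the shared core and gives 126 nM. Compound 2 `Cc1cc(C(=O)NCc2ccccn2)nn1Cc1cc(Cl)ccc1OCc1ccccc1` adds a (pyridin-2-yl)methyl group on the amide nitrogen and gives 25.1 nM. Compound 3 `Cc1cc(C(=O)NCc2cccnc2)nn1Cc1cc(Cl)ccc1OCc1ccccc1` carries the (pyridin-3-yl)methyl variant instead and gives 50.1 nM. Among the three numbers compound 3 stands second highest: it is separated from compound 2 by a 2.0-fold higher number from compound 2 to compound 3 (0.30 log units; within the scatter), and from compound 1 by a 2.5-fold lower number from compound 1 to compound 3 (0.40 log units; beyond the scatter).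

Compound 4 `CC(=O)Nc1cc(C)n(Cc2cc(Cl)ccc2OCc2ccccc2)n1` is not yet measured. The change from compound 3 is acetamido in place of ((pyridin-3-yl)methyl)carbamoyl on an aromatic carbon. For the measured compounds named here, two measured steps bear on it. Adding a pyridinylmethyl arm to the amide nitrogen helped in both cases, as a 5.0-fold lower number from compound 1 to compound 2 (0.70 log units; beyond the scatter) and a 2.5-fold lower number from compound 1 to compound 3 (0.40 log units; beyond the scatter) show, so removing that arm is expected to cost roughly what it earned. Going by the values given here, no measured pair shows the effect of turning the carboxamide round into an acetamido group, so that part of the change carries extra uncertainty in either direction. Compound 4 is therefore expected to give a higher number than compound 3, with the step estimated as a 4.0-fold higher number from compound 3 to compound 4 (0.60 log units; beyond the scatter). The estimate for compound 4 in this assay is 200 nM, with a range from 50 nM to 800 nM.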

Compound 4, half-maximal inhibitory concentration: 316 nM
Compound 4: middle estimate off by 1.6-fold (0.20 log units), on the low side, within the range that was stated.
By their numbers in this assay, from the lowest: compounds 2 and 3 (each within the scatter of the next); then compound 1; then compound 4.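

In this assay, the acetamido group gives a weaker result than even the plain carbamoyl group it replaces at this aromatic carbon (a 2.5-fold higher number from compound 1 to compound 4 (0.40 log units; beyond the scatter)), so this small group does not simply stand in for the primary carboxamide, even though neither carries a pyridine ring. The pyridinylmethyl arms therefore do not account for everything that matters at this position: swapping either complete ((pyridinyl)methyl)carbamoyl group for acetamido gives a larger change in the number (a 6.3-fold higher number from compound 3 to compound 4 (0.80 log units; beyond the scatter) and a 13-fold higher number from compound 2 to compound 4 (1.10 log units; beyond the scatter)), and the second of these steps is the largest in the set. Nothing available here explains why the acetamido group fares worse.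

The compounds shown leave open whether the acetamido form would regain strength if it carried a pyridine ring, as in a (pyridin-3-yl)acetamido group, which would show whether the arm can still help when the amide is attached through its nitrogen. They also leave open how a simple amine or a carboxylic acid on this same aromatic carbon would compare with the carbamoyl group of compound 1.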